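Swapping the Distal Pyridine for a Methylphenyl Ring

A few compounds are considered here, and "the series" means these few. Any claim that something is new, unique, unknown or untested is made for them only; others in the source may bear on it.

Compound 1 `CC(C)(C)[C@H](N)CN(C(=O)[C@@H]1C[C@H]1c1ccccc1)c1ccc(-c2ccccc2)cc1`: 11 nM
Compound 2 `CC(C)C[C@H](N)CN(C(=O)[C@@H]1C[C@H]1c1ccccc1)c1ccc(-c2ccncc2)cc1`: 13000 nM

The two measured compounds were tested in a functional assay for agonist activity at G protein-coupled receptor 88 (Homo sapiens), read by HTRF and cAMP accumulation; a lower number here means that less compound is needed, a higher number that more compound is needed for the effect. Compound 2 gives 13000 nM, the higher of the two numbers; compound 1 gives 11 nM, and the gap between them lies well beyond the scatter. For the measured compounds named here, compound 1 and compound 2 differ in two places at once, so no single step between them is defined.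

Compound 3 `Cc1cccc(-c2ccc(N(C[C@@H](N)CC(C)C)C(=O)[C@@H]3C[C@H]3c3ccccc3)cc2)c1` differs from compound 2 in one place only: 3-methylphenyl in place of pyridin-4-yl on an aromatic carbon. Going by the values given here, nothing measured isolates this change, but the only compound that carries a carbon-only distal ring, compound 1, sits at the low end of the two numbers, and compound 3 is expected to move in that direction rather than stay near compound 2. The step from compound 2 is estimated at a 130-fold lower number from compound 2 to compound 3 (2.11 log units; beyond the scatter). For compound 3 in this assay the expected value is 100 nM, within a range of 15 nM to 800 nM.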

Compound 3, half-maximal effective concentration: 1200 nM
For compound 3 the middle estimate is 12-fold (1.08 log units) below the measured one; the measured number lies above the stated range.
By their numbers in this assay, from the lowest: compound 1; then compound 3; then compound 2.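

In this assay the change from pyridin-4-yl to 3-methylphenyl on this aromatic carbon now has a measured size of its own (an 11-fold lower number from compound 2 to compound 3 (1.03 log units; beyond the scatter)), and that step lies beyond the scatter. For the compounds shown here, this is the first comparison of compounds that differ in one place only, and it shows that this position responds to the group placed on it, even though a six-membered aromatic ring stands there both before and after the change. No supporting data bear on why the number falls.

The step combines two changes, the loss of the ring nitrogen and the arrival of the methyl group, and the compounds shown cannot divide it between them. Also open, on these data alone, is how a methoxy group or a chlorine atom in place of that methyl would read in this assay.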